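Compound 3: one unmeasured step from compound 2

This account rests on a few compounds, and the source may have more. Where it says the series, first, only, none or still open, it means among the compounds named here.

In a functional assay on L1210 cells (Mus musculus) for inhibition, read by MTT assay, with a stated time of 72 h (on this read-out higher numbers stand for weaker inhibition and lower numbers for stronger inhibition), compound 1 (`COc1cc(NC(C)CCCNC(=O)Nc2cccc(Cl)c2)c2ncccc2c1`) gives 17000 nM, and compound 2 (`COc1cc(NC(C)CCCNC(=O)Nc2ccc(C(F)(F)F)cc2)c2ncccc2c1`) gives 7400 nM, the lower of the two numbers. Compound 3 (`COc1cc(NC(C)CCCNC(=O)NNC(=O)Nc2cccc(Cl)c2)c2ncccc2c1`) has not yet been measured. It has ((3-chlorophenyl)carbamoyl)amino in place of 4-(trifluoromethyl)phenyl on an amide-type nitrogen of compound 2: ((3-chlorophenyl)carbamoyl)amino in place of 4-(trifluoromethyl)phenyl on an amide-type nitrogen. For the measured compounds named here, only one measured step bears on this change. That modest step, a 2.3-fold lower number from compound 1 to compound 2 (0.36 log units; beyond the scatter), exchanged the aryl group alone, and compound 3 regains the 3-chlorophenyl of compound 1. Going by the values given here, no measured compound shows what the added carbamoyl amino portion does, so the expectation is loose. The expected step in this assay is a 2.0-fold higher number from compound 2 to compound 3 (0.31 log units; beyond the scatter), a modest move towards weaker inhibition. For compound 3 the estimate is 15000 nM, with an expected range from 5000 nM to 50000 nM.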

Compound 3, half-maximal inhibitory concentration: 27000 nM
For compound 3 the middle estimate is 1.8-fold (0.26 log units) below the measured one; the range from low to high includes it.
By their numbers in this assay, from the lowest: compound 2; then compounds 1 and 3 (each within the scatter of the next).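

In this assay, placing ((3-chlorophenyl)carbamoyl)amino on the amide-type nitrogen in place of 4-(trifluoromethyl)phenyl gives a 3.6-fold higher number from compound 2 to compound 3 (0.56 log units; beyond the scatter), so compound 2 remains clearly the strongest of the three. The comparison with the matching aryl group gives a 1.6-fold higher number from compound 1 to compound 3 (0.20 log units; within the scatter), which shows that this nitrogen tolerates the added carbamoyl amino portion without a change beyond the usual scatter in this assay. Nothing available explains either step. The compounds shown leave open whether ((4-(trifluoromethyl)phenyl)carbamoyl)amino would keep the lower number seen with 4-(trifluoromethyl)phenyl on the shorter linkage. They also leave open how a non-aromatic group such as cyclohexyl, or an aryl group carrying a carboxylic acid, would read out at this same nitrogen.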